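This account rests on a few compounds, and the source may have more. Where it says the series, first, only, none or still open, it means among the compounds named here.

Working notes on the series, read in a functional assay on MCF7 cells (Homo sapiens) for antiproliferative activity, read by MTT assay, with a stated time of 48 h; a higher number here means a weaker inhibitor, a lower number a stronger inhibitor. Compound 1 `O=[N+]([O-])c1cccc(-c2nn(-c3ccccc3)cc2C(Nc2nc3ccccc3s2)c2c(O)ccc3ccccc23)c1` gives 43900 nM, compound 2 `Oc1ccc2ccccc2c1C(Nc1nc2ccccc2s1)c1cn(-c2ccccc2)nc1-c1ccccc1` gives 48900 nM, and compound 3 `COc1ccc(-c2nn(-c3ccccc3)cc2C(Nc2nc3ccccc3s2)c2c(O)ccc3ccccc23)cc1` gives 17500 nM, the lowest of the three numbers, with both steps to it beyond the scatter. Next comes compound 4 `COc1ccc(-c2nn(-c3ccccc3)cc2C(Nc2nc3ccc(OC)cc3s2)c2c(O)ccc3ccccc23)cc1`, which carries methoxy in place of hydrogen on an aromatic carbon, read as 1,3-benzothiazol-2-yl to 6-methoxy-1,3-benzothiazol-2-yl. Going by the values given here, the closest precedent is the same exchange made elsewhere on the molecule, a 2.8-fold lower number from compound 2 to compound 3 (0.45 log units; beyond the scatter), a modest step. The change a 2.5-fold lower number from compound 1 to compound 3 (0.40 log units; beyond the scatter) is of similar size, whereas a 1.1-fold higher number from compound 1 to compound 2 (0.05 log units; within the scatter) stays within the scatter. Among the compounds with values here, no measured compound varies this place, so the precedent carries over only loosely. A small further fall in this assay is therefore expected, no larger than that modest step, and a result within the scatter would fit as well. The expected step is a 1.3-fold lower number from compound 3 to compound 4 (0.10 log units; within the scatter). For compound 4 the estimated value is 14000 nM, with an expected range of 5500 nM to 38000 nM.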

Compound 4, half-maximal inhibitory concentration: 41800 nM
Compound 4: middle estimate off by 3.0-fold (0.48 log units), on the low side, and the stated range ends below it.
By their numbers in this assay, from the lowest: compound 3; then compounds 4, 1 and 2 (each within the scatter of the next).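

In this assay, methoxy in place of hydrogen at the 6-methoxy-1,3-benzothiazol-2-yl position gives a 2.4-fold higher number from compound 3 to compound 4 (0.38 log units; beyond the scatter) and so runs opposite to the same exchange on the other aryl group, which gave a 2.8-fold lower number from compound 2 to compound 3 (0.45 log units; beyond the scatter) on the way to the 4-methoxyphenyl compound. Going by these compounds alone, the direction of this exchange therefore does not carry from one place on the molecule to the other, and at this position the only reading so far is a modest loss relative to the unsubstituted 1,3-benzothiazol-2-yl compound. Nothing at hand bears on why the step runs this way.

On these data alone, this position is described by hydrogen and methoxy alone, so whether a chloro group, an amine or a longer chain such as ethoxy would follow methoxy remains open. Also open, as far as these compounds go, is whether the step would hold with a group other than 4-methoxyphenyl on the shared core.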